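Cytotoxicity notes on compounds 1 to 4

The compounds below may be only part of what the source reports. "The series", "measured", "known", "first", "only" and "open" are said of these compounds alone.

Compound 1 `N#Cc1ccc(Nc2nc(Oc3ccnc4ccccc34)nc(N3CCN(c4ccccc4Cl)CC3)n2)cc1C(F)(F)F`: a limit, > 100000 nM
Compound 2 `COc1ccc(CN2CCN(c3nc(Nc4ccc(C#N)c(C(F)(F)F)c4)nc(Oc4ccnc5ccccc45)n3)CC2)c(OC)c1OC`: a limit, > 100000 nM
Compound 3 `N#Cc1ccc(Nc2nc(Oc3ccnc4ccccc34)nc(N3CCN(c4ccc(F)cc4)CC3)n2)cc1C(F)(F)F`: a limit, > 100000 nM

In a functional assay on DU-145 cells (Homo sapiens) for cytotoxicity, read by sulforhodamine B assay, with a stated time of 48 h (a higher number here means that more compound is tolerated, a lower number that less compound is tolerated), compound 3 gives only a limit, > 100000 nM. The same holds for the two other compounds, so all three sit at the limit of > 100000 nM in this assay, at which 3 of the 3 values shown sit. Among the compounds with values here, the single measured step, a step that the two limits leave unreadable from compound 1 to compound 3, therefore cannot be read for size or direction.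

Compound 4 `N#Cc1ccc(Nc2nc(Oc3ccnc4ccccc34)nc(N3CCN(Cc4ccccc4)CC3)n2)cc1C(F)(F)F` differs from compound 3 by benzyl in place of 4-fluorophenyl on an amine nitrogen in a ring. Within the data shown here, no measured step bears readably on this change, and the one neighbouring step is unreadable. Nothing in the series points to a step beyond the scatter in this assay in either direction, so compound 4 is expected to remain at the limit, with a number no higher from compound 3 to compound 4 (the limit leaves the size open) estimated as essentially none. For compound 4 the expected value is 100000 nM, range 50000 nM to 200000 nM.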

Compound 4, concentration lethal to 50% of the cells: > 100000 nM
Compound 4: no number, only a limit (the forecaster's own chance of this, stated with the estimate: 85%); the middle value lies on the limit itself.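

Compound 4 also gives only a limit, so no step from it to compound 1, compound 2 or compound 3 can be read: the limit of > 100000 nM in this assay, at which 4 of the 4 values shown sit.

The compounds shown leave open whether these groups on the ring amine nitrogen differ at all in cytotoxicity.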